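This account rests on a few compounds, and the source may have more. Where it says the series, first, only, none or still open, it means among the compounds named here.

Of the compounds shown here, three built on a shared core have been tested in a functional assay on MCF7 cells (Homo sapiens) for inhibition, read by CCK-8 assay, with a stated time of 48 h; on this read-out lower numbers stand for stronger inhibition and higher numbers for weaker inhibition. Compound 1 (`COc1cc(-c2cc3nccc(-c4cc(OC)c(OC)c(OC)c4)n3n2)cc(OC)c1OC`) gives only a limit, > 10000 nM. Compound 2 (`COc1cc(-c2cc3nccc(-c4c[nH]c5ccccc45)n3n2)cc(OC)c1OC`) also gives only a limit, > 10000 nM. Compound 3 (`COc1cc(-c2ccnc3cc(-c4ccc(Cl)cc4)nn23)cc(OC)c1OC`) is the only one of the three to return an actual number, 2320 nM, so it is the single numerical anchor for what follows.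

The next compound to be tested is compound 4 (`COc1cc(-c2ccnc3cc(-c4ccc5c(ccn5C)c4)nn23)cc(OC)c1OC`), which keeps the core of compound 3 and changes one group: 1-methyl-1H-indol-5-yl in place of 4-chlorophenyl on an aromatic carbon. In words, 1-methyl-1H-indol-5-yl takes the place of 4-chlorophenyl on an aromatic carbon. Among the compounds with values here, no measured pair yet shows what a change at this place does in this assay, so the expectation is a judgement that starts from compound 3 at 2320 nM and carries a wide margin. The expected step is toward stronger inhibition and beyond the usual scatter, estimated as a 12-fold lower number from compound 3 to compound 4 (1.06 log units; beyond the scatter). For compound 4 the estimated value is 200 nM, with an expected range from 12 nM to 3000 nM.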

Compound 4, half-maximal inhibitory concentration: 3 nM
Estimate against measurement, compound 4: 67-fold (1.82 log units) above; measured number outside the range, below it.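

In this assay, the aromatic carbon of the five-membered aromatic ring with 2 nitrogen proves highly sensitive to the group it carries: 1-methyl-1H-indol-5-yl in place of 4-chlorophenyl gives a 770-fold lower number from compound 3 to compound 4 (2.89 log units; beyond the scatter). With the core of compound 3 unchanged, this single replacement takes compound 4 to 3 nM, so this place can govern most of the inhibition seen on this read-out. The earlier results could not show this, as compound 1 and compound 2 returned limits rather than numbers and so gave no step to read: the limit of > 10000 nM in this assay, at which 2 of the 4 values shown sit.

A single step does not tell whether the gain comes from the second ring of the entering group or from its methyl on nitrogen. From the compounds shown here alone, whether an unsubstituted 1H-indol-5-yl, a 4-methoxyphenyl or a phenyl carrying an amine would hold this level at the same place remains open.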